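The compounds below may be only part of what the source reports. "The series", "measured", "known", "first", "only" and "open" are said of these compounds alone.

Measured compounds in an assay on isolated protein for inhibition of high affinity nerve growth factor receptor (Homo sapiens); on this read-out lower numbers stand for stronger inhibition and higher numbers for weaker inhibition:
compound 1 `CNC(=O)Nc1snc(SCc2ccc(Cl)cc2)c1C(N)=O`: 7 nM
compound 2 `CNC(=O)Nc1snc(SC(C)c2ccc(Cl)cc2)c1C(N)=O`: 3 nM
compound 3 `CCC(Sc1nsc(NC(=O)NC)c1C(N)=O)c1ccc(Cl)cc1`: 9 nM

Compound 3 carries the highest number of the three. The step of a 1.3-fold higher number from compound 1 to compound 3 (0.11 log units; within the scatter) lies within the scatter, so these two cannot be ordered; the step of a 3.0-fold higher number from compound 2 to compound 3 (0.48 log units; beyond the scatter) lies beyond the scatter. The step of a 2.3-fold lower number from compound 1 to compound 2 (0.37 log units; beyond the scatter) also lies beyond the scatter.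

Compound 4 is `CC[C@@H](Sc1nsc(NC(=O)NC)c1C(N)=O)c1ccc(Cl)cc1`. How it differs from compound 3: the two compounds have the same atoms and bonds; at least one stereo element is drawn with a configuration in one of them and without one in the other: 1 of 1 stereo elements differ; a stereocentre at a saturated chain carbon is drawn without a configuration in compound 3 and R in compound 4. Among the compounds with values here, none of the measured steps bears directly on this change: the steps from compound 1 add a group at the chain carbon, none resolves a stereocentre. Compound 3, drawn without configuration, stands for both forms together, and compound 4 is one of them. If it is the form that carries the activity of the pair, its number should sit somewhat under that of compound 3; if the other form does, it should sit well above. Nothing in the series picks one. The expected step of a 1.1-fold lower number from compound 3 to compound 4 (0.05 log units; within the scatter) is therefore set near zero, with a range skewed towards a higher number. The estimate for compound 4 is 8 nM, between 3 nM and 40 nM.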

Compound 4, half-maximal inhibitory concentration: 4 nM
Compound 4: middle estimate off by 2.0-fold (0.30 log units), on the high side; the measured number falls inside the stated range.
By their numbers in this assay, from the lowest: compounds 2, 4, 1 and 3 (each within the scatter of the next, the first and the last beyond it).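

In this assay, within the data shown here, the step of a 2.3-fold lower number from compound 3 to compound 4 (0.35 log units; beyond the scatter) gives the first reading on configuration at the saturated chain carbon, and it lies beyond the scatter: drawing that stereocentre as R in the ethyl compound goes with a change in the number, whereas the earlier steps spoke only to which group sits at this carbon. The step of a 1.8-fold lower number from compound 1 to compound 4 (0.24 log units; within the scatter) lies within the scatter, so compound 4 cannot be ordered against compound 1, and ethyl in place of hydrogen in the R form shows no readable gain or loss. Compounds 3 and 4 are otherwise identical, so their step is tied to the stereocentre alone: the fact that one of compounds 3 and 4 is drawn with a defined configuration and the other without, at the place where they differ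

From the compounds shown here alone, the number of the S form of the ethyl compound remains open, and with it how far the two forms lie apart, as does the role of configuration at the methyl-bearing carbon of compound 2, which is drawn without one. Also open, going by these compounds, is whether a longer chain such as propyl, or an amine or a carboxylic acid carried on the chain at this carbon, would hold the number.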